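Taking the 2-cyanoethyl group off compound 3

The source may hold more compounds than are shown below. What is called first, only, known or untested is meant among the compounds shown, and "the series" means these compounds.

Measured so far in a functional assay (muscle tissue) with Rattus norvegicus as the target; on this read-out lower numbers stand for an effect already at smaller amounts and higher numbers for an effect only at larger amounts of compound
compound 1 `CNC(=O)C1=CC(C)(C)Oc2ccc([N+](=O)[O-])cc21` gives 10.7 nM
compound 2 `CC1(C)C=C(C(=O)NCC2CC2)c2cc([N+](=O)[O-])ccc2O1` gives 6.61 nM
compound 3 `CC1(C)C=C(C(=O)NCCC#N)c2cc([N+](=O)[O-])ccc2O1` gives 2.82 nM

Compound 3 has the lowest number of the three, beyond the scatter from both others. Compound 4 `CC1(C)C=C(C(N)=O)c2cc([N+](=O)[O-])ccc2O1` has not yet been measured. It carries hydrogen in place of 2-cyanoethyl on an amide-type nitrogen. For the measured compounds named here, no measured compound has hydrogen there, so the evidence is indirect. Going by the values given here, two steps bear on the change: the step of a 3.8-fold lower number from compound 1 to compound 3 (0.58 log units; beyond the scatter) and the step of a 2.3-fold lower number from compound 2 to compound 3 (0.37 log units; beyond the scatter) are both modest, while the step of a 1.6-fold lower number from compound 1 to compound 2 (0.21 log units; within the scatter) stays within the scatter. Read in reverse, these steps suggest that losing the 2-cyanoethyl group should raise the number. Compound 4 also lacks the group that compound 1 keeps on that nitrogen, so the rise may be somewhat larger than the largest measured step. The expected change is a 5.0-fold higher number from compound 3 to compound 4 (0.70 log units; beyond the scatter) and would lie beyond the scatter. For compound 4 the estimate is 14 nM with an expected range from 5 nM to 40 nM in this reading.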

Compound 4, half-maximal effective concentration: 363 nM
The estimate for compound 4 lay 26-fold (1.41 log units) below the measured number, and the stated range ends below it.
By their numbers in this assay, from the lowest: compound 3; then compounds 2 and 1 (each within the scatter of the next); then compound 4.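

In this assay, for the compounds shown here, the amide-type nitrogen turns out to be far less forgiving than the earlier compounds suggested: putting hydrogen in place of its group gives large steps in all three comparisons (a 130-fold higher number from compound 3 to compound 4 (2.11 log units; beyond the scatter) and a 55-fold higher number from compound 2 to compound 4 (1.74 log units; beyond the scatter) and a 34-fold higher number from compound 1 to compound 4 (1.53 log units; beyond the scatter)). Methyl, cyclopropylmethyl and 2-cyanoethyl differ from one another only slightly by comparison, so among these compounds, having one of these groups on that nitrogen matters much more than which group it is. The data shown give no explanation for this large difference.

The compounds shown leave open how little is needed beyond methyl and whether a longer chain, or a chain ending in an amine or a carboxylic acid, would stay with compounds 1, 2 and 3. They also leave open what a dimethylamide, with no amide hydrogen left, would give.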